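Replacing 3,4-dimethoxyphenyl with 2-(trifluoromethyl)phenyl in compound 1

The source may report more compounds than this note shows. Statements on the series, on what has been measured and on what is new or still open speak of the compounds shown alone.

Of the compounds shown here, three that share a common core have been tested so far in a functional assay on the whole organism (strain Kunming) with Mus musculus as the target, with a stated time of 0.5 h; on this read-out lower numbers stand for an effect already at smaller amounts and higher numbers for an effect only at larger amounts of compound. Compound 1, `COc1cc(OC)c(OC)cc1/C=C/COC(=O)/C=C/c1ccc(OC)c(OC)c1`, gives 140 umol/kg, which puts it at the upper end of the numbers measured. Compound 2, `COc1cc(OC)c(OC)cc1/C=C/COC(=O)/C=C/c1c(OC)ccc(OC)c1OC`, gives 120 umol/kg, and this value lies within the usual scatter of compound 1, so the two cannot be told apart. Compound 3, `COc1cc(OC)c(OC)cc1/C=C/COC(=O)/C=C/c1cc(OC)c(OC)c(OC)c1OC`, gives 65.1 umol/kg, a smaller number that lies beyond the scatter from compound 1.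

Compound 4, `COc1cc(OC)c(OC)cc1/C=C/COC(=O)/C=C/c1ccccc1C(F)(F)F`, has not yet been measured. It keeps the core of compound 1 and changes one group, on a double-bonded chain carbon bound to a double-bonded chain carbon: 2-(trifluoromethyl)phenyl in place of 3,4-dimethoxyphenyl on a double-bonded chain carbon bound to a double-bonded chain carbon. Among the measured compounds shown here, no tested compound carries a trifluoromethyl group, so the data hold no direct guide to this swap. The expectation therefore rests on the narrow spread seen so far, from compound 3 at 65.1 umol/kg to compound 1 at 140 umol/kg. The expected change is small, a 1.4-fold lower number from compound 1 to compound 4 (0.15 log units; within the scatter), towards a slightly lower number but not beyond the scatter. For compound 4 the estimated value in this assay is 100 umol/kg, with an expected range from 45 umol/kg to 250 umol/kg.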

Compound 4, dose for half-maximal effect: 203 umol/kg
Estimate against measurement, compound 4: 2.0-fold (0.31 log units) below; low and high end bracket the measured number.
By their numbers in this assay, from the lowest: compounds 3, 2, 1 and 4 (each within the scatter of the next, the first and the last beyond it).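

In this assay, putting 2-(trifluoromethyl)phenyl in place of 3,4-dimethoxyphenyl on a double-bonded chain carbon bound to a double-bonded chain carbon gives a 1.5-fold higher number from compound 1 to compound 4 (0.16 log units; within the scatter), so the two compounds cannot be told apart. Among the compounds shown here, this is the first compound with no methoxy group on this ring, and the swap keeps the heavy-atom count of the group while taking its hydrogen-bond acceptors from 2 to 0, so in this one pair a quite different set of atoms on the ring leaves the read-out within the scatter. For the compounds shown here, no measurement at hand explains why the read-out stays so close, and this single pair shows only that the swap is tolerated, not what each part of it contributes.

The compounds shown leave open how much of this step belongs to the trifluoromethyl group and how much to the two methoxy groups that leave, which a plain phenyl ring at this place would help to separate. They also leave open how this place responds to a ring carrying an amine or a carboxylic acid, whose effect on this read-out cannot be judged from these compounds.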